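A few compounds are considered here, and "the series" means these few. Any claim that something is new, unique, unknown or untested is made for them only; others in the source may bear on it.

Two compounds of this series have numbers in a functional assay on Jurkat cells (Homo sapiens) for inhibition, read by MTT assay, tested at 10 uM; a higher number here means more inhibition at the concentration tested (going by the name of the read-out), a lower number less inhibition. Compound 1 `N#Cc1ccc2c(c1)CCN2S(=O)(=O)c1ccc(-c2cnc(C3CC3)o2)cc1` gives 15.8%, and compound 2 `O=S(=O)(c1ccc(-c2nnc(C3CC3)o2)cc1)N1CCc2ccccc21` gives 31.7%. Compound 2 stands highest of the two; its nearest neighbour is compound 1, which lies beyond the usual scatter below it. Compound 3 `O=S(=O)(c1ccc(-c2cnc(C3CC3)s2)cc1)N1CCc2ccccc21` has not been measured. It differs from compound 2 in one place: 2-cyclopropyl-1,3-thiazol-5-yl in place of 5-cyclopropyl-1,3,4-oxadiazol-2-yl on an aromatic carbon. Within the data shown here, no measured pair shows this exchange, so the size of its effect rests on nothing measured here. Both measured values are modest, and the exchange keeps the cyclopropyl on a five-membered aromatic ring at the same place, so a step of small size in either direction, or none beyond the scatter, is expected. For compound 3 the expected value in this assay is 28%, with a range from 12% to 45%. The expected step of a number 3.7 percentage points lower from compound 2 to compound 3 (within the scatter) is small and within the scatter.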

Compound 3, a percentage reported as inhibition, at one concentration (the size of the read-out at that concentration, not a potency): 29.8%
Estimate against measurement, compound 3: 1.8 percentage points below, within the range that was stated.
By their numbers in this assay, from the lowest: compound 1; then compounds 3 and 2 (each within the scatter of the next).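

In this assay, among these compounds, the exchange of 5-cyclopropyl-1,3,4-oxadiazol-2-yl for 2-cyclopropyl-1,3-thiazol-5-yl gives a number 1.9 percentage points lower from compound 2 to compound 3 (within the scatter) and is the first one-place comparison at this position, on an aromatic carbon para to a large group. At this position, a five-membered aromatic ring with 3 hetero atoms and one with 2 hetero atoms, each carrying cyclopropyl, are not told apart by this read-out. Nothing measured here bears on why the two groups read alike.

Compound 1 differs from compound 2 in more than one place, so the part played by its nitrile cannot be read from these values. As far as these compounds go, whether a carboxylic acid or a primary amide at this position, or a tert-butyl in place of the cyclopropyl, would give a similar reading stays open.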